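Cytotoxicity of Benzylidene Cyclohexanones: Bromophenyl to Dihydroxyphenyl

A few compounds are considered here, and "the series" means these few. Any claim that something is new, unique, unknown or untested is made for them only; others in the source may bear on it.

Compound 1, `COc1cccc(/C=C2\CCC/C(=C\c3ccc(O)cc3)C2=O)c1OC`, reaches only the limit of an ADME assay on NHDF cells (Homo sapiens) for cytotoxicity, read by MTT assay, with a stated time of 72 h (on this read-out higher numbers stand for weaker inhibition and lower numbers for stronger inhibition), giving > 50000 nM.
Compound 2, `COc1cccc(/C=C2\CCC/C(=C\c3cc(Cl)cc(Cl)c3)C2=O)c1OC`, gives 21600 nM in this assay.
Compound 3, `COc1ccc(/C=C2\CCC/C(=C\c3ccccc3Br)C2=O)cc1OC`, gives 21800 nM in this assay.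

Compound 3 has the highest number of the two that are numbers, and compound 2 sits within the scatter of it. Compound 4, `COc1ccc(/C=C2\CCC/C(=C\c3ccc(O)c(O)c3)C2=O)cc1OC`, differs from compound 3 in one place: 3,4-dihydroxyphenyl in place of 2-bromophenyl on a double-bonded chain carbon bound to a double-bonded ring carbon. Among the measured compounds shown here, the one measured step that bears on this is an at least 2.3-fold lower number from compound 1 to compound 2 (0.36 log units; beyond the scatter), where the hydroxylated ring gave the higher number; compound 4 carries the hydroxylated ring, so the change runs the other way. Compound 4 is therefore expected to show a rise, a 2.3-fold higher number from compound 3 to compound 4 (0.36 log units; beyond the scatter), and a limit is quite possible because of the limit of > 50000 nM in this assay, at which 1 of the 3 values shown sits. The estimate for compound 4 is 50000 nM, between 20000 nM and 120000 nM.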

Compound 4, half-maximal inhibitory concentration: 25200 nM
Compound 4: middle estimate off by 2.0-fold (0.30 log units), on the high side, and the stated range covers the measured number.
By their numbers in this assay, from the lowest: compounds 2, 3 and 4 (each within the scatter of the next). At a limit, above all of these: compound 1.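

In this assay, 3,4-dihydroxyphenyl in place of 2-bromophenyl on a double-bonded chain carbon bound to a double-bonded ring carbon gives a 1.2-fold higher number from compound 3 to compound 4 (0.06 log units; within the scatter). Thus, on the core of compound 3, this ring change leaves no difference beyond the scatter, unlike an at least 2.3-fold lower number from compound 1 to compound 2 (0.36 log units; beyond the scatter) on the core of compound 1. Compound 1 alone stays at a limit, which compound 4, despite its hydroxylated ring, does not share: the limit of > 50000 nM in this assay, at which 1 of the 4 values shown sits.

Still open, from the compounds shown here alone, is whether an amine or a carboxylic acid on this ring would also stay within the scatter of compound 3. Also open, going by these compounds, is how 3,4-dihydroxyphenyl would read on the core of compound 1.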